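The compounds below may be only part of what the source reports. "The series", "measured", "known", "first", "only" and "open" are said of these compounds alone.

Measured so far:
compound 1 `Cc1ccsc1[C@@H]1C[C@H](O)Cc2ccccc2N1`, 616000 nM in an ADME assay on Vero cells (Chlorocebus sabaeus) for cytotoxicity; a lower number here means that less compound is tolerated, a higher number that more compound is tolerated
compound 2 `O[C@@H]1Cc2cc(F)ccc2N[C@H](c2cccs2)C1`, 218000 nM
compound 3 `Cc1ccc([C@@H]2C[C@H](O)Cc3cc(F)ccc3N2)s1`, 801000 nM

Compound 3 gives the highest number of the three in this assay; compound 1 lies nearest, within the scatter, while compound 2 stands furthest, beyond it. Among the compounds with values here, the only measured step that changes a single place, a 3.7-fold higher number from compound 2 to compound 3 (0.57 log units; beyond the scatter), concerns a methyl in place of hydrogen on an aromatic carbon, which is not the change at hand. Compound 4 `Cc1ccsc1[C@@H]1C[C@H](O)Cc2cc(F)ccc2N1` differs from compound 3 by 3-methylthiophen-2-yl in place of 5-methylthiophen-2-yl on a saturated ring carbon. Within the data shown here, no measured step bears directly on this change. Compound 1 carries the same 3-methylthiophen-2-yl group as compound 4 but lacks the fluorine on the shared core, and because compound 1 gives 616000 nM while compound 3 gives 801000 nM, two values within the scatter of each other, no step beyond the scatter is expected in this assay. Compound 4 is therefore estimated at 650000 nM, with a range from 300000 nM to 1300000 nM. This implies an expected 1.2-fold lower number from compound 3 to compound 4 (0.09 log units; within the scatter), within the scatter.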

Compound 4, half-maximal cytotoxic concentration: 243000 nM
For compound 4 the middle estimate is 2.7-fold (0.43 log units) above the measured one, and the stated range ends above it.
By their numbers in this assay, from the lowest: compounds 2 and 4 (each within the scatter of the next); then compounds 1 and 3 (each within the scatter of the next).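

In this assay, the position of the methyl on the ring carried by the saturated ring carbon matters: 3-methylthiophen-2-yl in place of 5-methylthiophen-2-yl gives a step beyond the scatter (a 3.3-fold lower number from compound 3 to compound 4 (0.52 log units; beyond the scatter)). Methyl in place of hydrogen on an aromatic carbon therefore does not act the same way in each case, since the step beyond the scatter seen earlier (a 3.7-fold higher number from compound 2 to compound 3 (0.57 log units; beyond the scatter)) contrasts with one within the scatter here (a 1.1-fold higher number from compound 2 to compound 4 (0.05 log units; within the scatter)). Within the data shown here, the compounds also give the first reading for adding a fluorine to the shared core, and that step lies beyond the scatter (a 2.5-fold lower number from compound 1 to compound 4 (0.40 log units; beyond the scatter)).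

From the compounds shown here alone, whether an ethyl or a methoxy group in place of the methyl would follow compound 3 or compound 4 remains open. Nothing available gives a reason for these steps.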